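Adding a Nitrile to the Phenoxy Ring of Compound 2

The compounds below may be only part of what the source reports. "The series", "measured", "known", "first", "only" and "open" are said of these compounds alone.

Compound 1, `CN(Cc1ccc(OCCCNC(=N)N)cc1)c1nc2ccc(Oc3ccccc3)cc2s1`, gives 498000 nM in an assay on cells for inhibition of Voltage-dependent T-type calcium channel subunit alpha-1H (Homo sapiens), read by FLIPR and calcium flux, with stated times of 600 s and 300 s; a higher number here means a weaker inhibitor, a lower number a stronger inhibitor.
Compound 2, `CN(Cc1ccc(OCCCN)cc1)c1nc2ccc(Oc3ccccc3)cc2s1`, gives 95000 nM.
Compound 3, `CN(C)CCCOc1ccc(CNc2nc3ccc(Oc4cccc(C(F)(F)F)c4)cc3s2)cc1`, gives 110000 nM.

Going by the values given here, compound 2 has the lowest number of the three; its gap to compound 3 lies within the scatter, while the only single-place step, a 5.2-fold lower number from compound 1 to compound 2 (0.72 log units; beyond the scatter), sits beyond it and concerns the amine end, not the phenoxy ring. Compound 4, `CN(Cc1ccc(OCCCN)cc1)c1nc2ccc(Oc3ccc(C#N)cc3)cc2s1`, differs from compound 2 by cyano in place of hydrogen on an aromatic carbon. Among the compounds with values here, no measured step alters this ring alone; compound 3 carries a trifluoromethyl on it but also differs elsewhere, so its value gives no direct guide. Compound 4 is therefore expected to show no step beyond the scatter, no change at the digits printed from compound 2 to compound 4 (within the scatter). The estimated value of compound 4 is 95000 nM, with a range from 30000 nM to 300000 nM.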

Compound 4, half-maximal inhibitory concentration: 328000 nM
For compound 4 the middle estimate is 3.5-fold (0.54 log units) below the measured one, and the stated range ends below it.
By their numbers in this assay, from the lowest: compounds 2 and 3 (each within the scatter of the next); then compounds 4 and 1 (each within the scatter of the next).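

Cyano in place of hydrogen on this aromatic carbon, para to a large group, gives a 3.5-fold higher number from compound 2 to compound 4 (0.54 log units; beyond the scatter) in this assay, so the higher number means a weaker inhibitor. This is the first change shown that alters the phenoxy ring alone, and it shows that this position is not indifferent to what it carries. Nothing measured here explains the shift.

From the compounds shown here alone, whether a fluorine or a methoxy group on the same carbon would shift the number in the same direction remains open. So does whether a nitrile elsewhere on this ring would do so.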